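The compounds below may be only part of what the source reports. "The series", "measured", "known", "first", "only" and "open" are said of these compounds alone.

Compound 1, `O=C(/C=C/c1ccc([N+](=O)[O-])cc1)Nc1cc(Sc2ncn[nH]2)c(O)c2ccccc12`: in a functional assay on HCT-116 cells (Homo sapiens) for antiproliferative activity, read by MTT assay, with a stated time of 48 h (a lower number here means a stronger inhibitor, a higher number a weaker inhibitor), compound 1 gives > 100000 nM, which is a limit of the assay.
Compound 2, `COc1ccc(C(=O)Nc2cc(Sc3ncn[nH]3)c(O)c3ccccc23)cc1`: in this assay compound 2 gives > 100000 nM, again a limit of the assay.

Compound 2 therefore stands nowhere on a scale of numbers: only a limit is reported for it, and the same holds for every other value shown here (the limit of > 100000 nM in this assay, at which 2 of the 2 values shown sit). Compound 3, `O=C(/C=C/c1ccc(Cl)cc1)Nc1cc(Sc2ncn[nH]2)c(O)c2ccccc12`, differs from compound 2 in one place, (2-(4-chlorophenyl)ethenyl in place of 4-methoxyphenyl on a carbonyl carbon). Within the data shown here, no step between two measured compounds is available, so the size of the change cannot be read from any comparison. Compound 1 already carries a 2-arylethenyl group on the same carbonyl carbon and sits at the limit, as does compound 2 with its 4-methoxyphenyl group. Compound 3 is therefore expected to stay at or near the limit as well. The step from compound 2 to compound 3 is estimated at a step that the limit leaves unreadable from compound 2 to compound 3, that is, no movement beyond the scatter. For compound 3 the expected value in this assay is 120000 nM, within a range from 40000 nM to 400000 nM.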

Compound 3, half-maximal inhibitory concentration: > 100000 nM
Compound 3: no number, only a limit; the forecaster's own chance of this, stated with the estimate: 75%; the middle value is on the limit's open side.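

In this assay compound 3 gives > 100000 nM which is again a limit of the assay. Among these compounds, no step from compound 1 or compound 2 to compound 3 can therefore be read. The compounds shown leave open how far each lies past this limit, and whether either change alters antiproliferative activity at all.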